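The compounds below may be only part of what the source reports. "The series", "measured", "known", "first", "only" and "open" are said of these compounds alone.

Measured compounds in a functional assay on SMMC-7721 cells (Homo sapiens) for inhibition, read by MTT assay, with a stated time of 48 h; on this read-out higher numbers stand for weaker inhibition and lower numbers for stronger inhibition:
- compound 1 `COc1ccc(-c2cc(NC(=O)Nc3ccncc3)cc(C(F)(F)F)c2)cn1`: > 300000 nM, a limit of this assay, not a number.
- compound 2 `COc1ccc(-c2ccc(OC(F)(F)F)c(NC(=O)Nc3ccncc3)c2)cn1`: "not determined" (no result reported) in this assay.
- compound 3 `COc1ccc(-c2cc(NC(=O)Nc3nccs3)cc(C(F)(F)F)c2)cn1`: 36200 nM.

Going by the values given here, the one counted change runs from compound 1 to compound 3, (1,3-thiazol-2-yl in place of pyridin-4-yl on an amide-type nitrogen), and in this assay it gives an at least 8.2-fold lower number from compound 1 to compound 3 (0.91 log units; beyond the scatter). The step is only known as a bound because of the limit of > 300000 nM in this assay, at which 1 of the 3 values shown sits. Compound 2 shares the pyridin-4-yl urea end of compound 1 but sits on a different core; the difference between the two cores is not broken down here.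

Compound 4 `COc1ccc(-c2ccc(OC(F)(F)F)c(NC(=O)Nc3nccs3)c2)cn1`, not yet measured, carries the same kind of change on the core of compound 2: 1,3-thiazol-2-yl in place of pyridin-4-yl on an amide-type nitrogen. The place lines read the same, so it is the same kind of change. For compound 2 no number is available in this assay, so the step from compound 2 to compound 4 cannot be bounded from its own start point; the expectation leans instead on compound 3 and its value 36200 nM, the only measured thiazolyl urea. Compound 4 is expected near 35000 nM, within 8000 nM to 150000 nM.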

Compound 4, half-maximal inhibitory concentration: 44100 nM
Estimate against measurement, compound 4: 1.3-fold (0.10 log units) below, and the stated range covers the measured number.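

No new step can be read: in this assay compound 2 stands as "not determined" (no result reported), so the pair of compound 2 and compound 4 gives no comparison. Still open are the effect of the two cores and the exact size of 1,3-thiazol-2-yl in place of pyridin-4-yl, which remains a bound on the core of compound 1, set by a limit: the limit of > 300000 nM in this assay, at which 1 of the 4 values shown sits.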